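Removing the side-chain hydroxy: compounds 1 to 4

The compounds below may be only part of what the source reports. "The series", "measured", "known", "first", "only" and "open" are said of these compounds alone.

Compound 1 `C=C1C(=O)[C@H]2C[C@]1(O)CC1=C2[C@]2(C)CCCC(C)(C)[C@H]2CC1` and compound 2 `C=C1C(=O)[C@H]2C[C@]1(O)CC1=C2[C@]2(C)CCC[C@](C)(CO)[C@H]2CC1` share a core and differ by one change: hydrogen in place of hydroxy on a saturated chain carbon bound to a saturated ring carbon. In a functional assay on PC-3 cells (Homo sapiens) for cytotoxicity, read by MTT assay, with a stated time of 24 h (a lower number here means a stronger inhibitor, a higher number a weaker inhibitor), compound 1 gives 2200 nM and compound 2 gives 8200 nM; this change made a 3.7-fold lower number from compound 2 to compound 1 (0.57 log units; beyond the scatter). Compound 3 `C[C@@H]1C(=O)[C@H]2C[C@]1(O)CC1=C2[C@]2(C)CCC[C@](C)(CO)[C@H]2CC1` gives only a limit in this assay, namely > 50000 nM. The difference between the core of compound 3 and the core of compound 2 is not broken down here. Compound 4 `C[C@@H]1C(=O)[C@H]2C[C@]1(O)CC1=C2[C@]2(C)CCCC(C)(C)[C@H]2CC1` is to be measured in this assay; it differs from compound 3 by hydrogen in place of hydroxy on a saturated chain carbon bound to a saturated ring carbon, the same kind of change as from compound 2 to compound 1, at a place described in the same words. The expected step is an at least 1.6-fold lower number from compound 3 to compound 4 (0.22 log units; that floor lies within the scatter), resting on a 3.7-fold lower number from compound 2 to compound 1 (0.57 log units; beyond the scatter); because compound 3 sits at the limit of > 50000 nM in this assay, at which 1 of the 3 values shown sits, the result may again be a limit. Compound 4 is expected to give about 30000 nM, between 10000 nM and 100000 nM.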

Compound 4, half-maximal inhibitory concentration: > 50000 nM
Compound 4 ended at the assay's limit; the forecaster's own chance of this, stated with the estimate: 45%; middle value at least 1.6-fold (0.22 log units) from the limit.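

Compound 4 gives only a limit in this assay, as compound 3 does, so no step between them can be read: the limit of > 50000 nM in this assay, at which 2 of the 4 values shown sit.

From the compounds shown here alone, whether hydrogen in place of hydroxy shifts the number on the core of compound 3 at all remains open.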